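Fluoro for methoxy on the aryl ring

This account rests on a few compounds, and the source may have more. Where it says the series, first, only, none or still open, it means among the compounds named here.

Compound 1 `COC(=O)C1=C(C)N=C(C)/C(=C(\O)OC)C1c1ccccc1OC` gives 57.5 nM
Compound 2 `COC(=O)C1=C(C)N=C(C)/C(=C(\O)OC)C1c1cc([N+](=O)[O-])ccc1Cl` gives 30.2 nM

Both numbers come from a functional assay (muscle tissue) with Cavia porcellus as the target (on this read-out higher numbers stand for an effect only at larger amounts of compound and lower numbers for an effect already at smaller amounts), and there compound 1 at 57.5 nM stands within the usual scatter of compound 2 at 30.2 nM on the two numbers available. Compound 3 `COC(=O)C1=C(C)N=C(C)/C(=C(\O)OC)C1c1ccccc1F` differs from compound 1 by fluoro in place of methoxy on an aromatic carbon with fluoro in place of methoxy on an aromatic carbon, ortho to a large group. Going by the values given here, no measured pair shows this change, so the expectation in this assay is weakly founded. The estimated 1.3-fold lower number from compound 1 to compound 3 (0.11 log units; within the scatter) is expected to stay within the scatter, with no clear direction. Compound 3 is estimated at 45 nM with an expected range of 12 nM to 160 nM in this estimate.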

Compound 3, half-maximal effective concentration: 42.7 nM
Estimate against measurement, compound 3: 1.1-fold (0.02 log units) above, within the range that was stated.
By their numbers in this assay, from the lowest: compounds 2, 3 and 1 (each within the scatter of the next).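

In this assay, going by these compounds alone, the step of a 1.3-fold lower number from compound 1 to compound 3 (0.13 log units; within the scatter) gives the first reading of a single change at this position: fluoro in place of methoxy, on an aromatic carbon, ortho to a large group. Going from 2-methoxyphenyl to 2-fluorophenyl thus leaves the number within the scatter, so this one exchange shows no clear effect in either direction. No measurement shown here offers an explanation of this result. Going by these compounds, whether an amine or a hydroxyl group at this place would move the number beyond the scatter remains open.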